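Changing the Amino-Acid Side Chain on a Shared Core

A few compounds are considered here, and "the series" means these few. Any claim that something is new, unique, unknown or untested is made for them only; others in the source may bear on it.

Of the compounds shown here, two built on one shared core have been tested in a functional assay on BGC-823 cells (Homo sapiens) for cytotoxicity, read by MTT assay, with a stated time of 24 h; on this read-out lower numbers stand for stronger inhibition and higher numbers for weaker inhibition. Compound 1 `COC(=O)CCNC(=O)Cn1cc(C2=C(c3c[nH]c4ccccc34)C(=O)N(C)C2=O)c2ccccc21` gives 44900 nM in this assay. For the measured compounds named here, compound 2 `COC(=O)CC[C@@H](NC(=O)Cn1cc(C2=C(c3c[nH]c4ccccc34)C(=O)N(C)C2=O)c2ccccc21)C(=O)OC` gives 25000 nM, and the only measured step, a 1.8-fold lower number from compound 1 to compound 2 (0.25 log units; within the scatter), shows that the two numbers sit within the scatter of each other, so neither compound can be called the more potent of the pair. Compound 3 `COC(=O)[C@@H](CC(C)C)NC(=O)Cn1cc(C2=C(c3c[nH]c4ccccc34)C(=O)N(C)C2=O)c2ccccc21` is the next variation: isopropyl in place of (methoxycarbonyl)methyl on a saturated chain carbon, two bonds along the chain from an amide-type nitrogen and a carbonyl carbon. This is again a change confined to the chain attached to the amide-type nitrogen, the same part of the molecule that was altered between compound 1 and compound 2 without a shift beyond the scatter. Going by the values given here, with only that one step to lean on, the expected result for compound 3 is a 1.1-fold higher number from compound 2 to compound 3 (0.05 log units; within the scatter), meaning no clear step in either direction. Compound 3 is therefore estimated at 28000 nM, with a range from 10000 nM to 70000 nM.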

Compound 3, half-maximal inhibitory concentration: 45500 nM
Estimate against measurement, compound 3: 1.6-fold (0.21 log units) below; the measured number falls inside the stated range.
By their numbers in this assay, from the lowest: compounds 2, 1 and 3 (each within the scatter of the next).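

In this assay, isopropyl replaces (methoxycarbonyl)methyl, so the group that leaves has hydrogen-bond acceptors and the group that enters has none, yet the outcome is a 1.8-fold higher number from compound 2 to compound 3 (0.26 log units; within the scatter) and no clear shift. With 1-(methoxycarbonyl)-3-methylbutyl in place of 2-(methoxycarbonyl)ethyl on the amide-type nitrogen, the step is a 1.0-fold higher number from compound 1 to compound 3 (0.01 log units; within the scatter) and again no clear shift, so in these three compounds neither an added ester nor a branched carbon chain moves the number beyond the scatter. No measured evidence is available to explain this flat result.

Every compound shown keeps at least one methyl ester on this chain, so the effect of a carboxylic acid or an amine in its place remains open. Also open, as far as these compounds go, is whether a benzyl group here would produce a step beyond the scatter.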